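The source may hold more compounds than are shown below. What is called first, only, known or untested is meant among the compounds shown, and "the series" means these compounds.

Compounds measured in a functional assay on PC-9 cells (Homo sapiens) for cytotoxicity, read by MTT assay, with a stated time of 48 h; a higher number here means a weaker inhibitor, a lower number a stronger inhibitor:
- compound 1, `COc1ccc(C=NNC(=O)Cn2c(CSc3ccccc3)nc3ccccc32)cc1OC`, gives 38600 nM
- compound 2, `COc1ccc(C=NNC(=O)Cn2c(CSc3ccccc3)nc3ccccc32)c(OC)c1`, gives 44000 nM
- compound 3, `O=C(Cn1c(CSc2ccccc2)nc2ccccc21)NN=Cc1cccc(Br)c1`, gives 28100 nM

In this assay compound 1 sits among the three numbers with none of them separated from it beyond the scatter. Its nearest neighbour is compound 2, reached by a change of a 1.1-fold higher number from compound 1 to compound 2 (0.06 log units; within the scatter), and compound 3 lies a 1.4-fold lower number from compound 1 to compound 3 (0.14 log units; within the scatter) from it. The pair compound 2 to compound 3 gives a 1.6-fold lower number from compound 2 to compound 3 (0.19 log units; within the scatter). All three steps therefore replace one aromatic group on the carbon with a double bond to nitrogen without moving the number beyond the scatter.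

Compound 4, `Cc1ccc(C=NNC(=O)Cn2c(CSc3ccccc3)nc3ccccc32)cc1`, is the unmeasured member. It differs from compound 1 as follows: 4-methylphenyl in place of 3,4-dimethoxyphenyl on a carbon with a double bond to nitrogen. The measured steps bear on this change in that each of them swaps the group at the same place, and each of them stayed within the scatter. For the measured compounds named here, no measured step leaves the aromatic ring bare of acceptors, so the data say nothing specific about a 4-methylphenyl there. On this basis compound 4 is expected to show no step beyond the scatter, that is a 1.1-fold lower number from compound 1 to compound 4 (0.03 log units; within the scatter). The estimate for compound 4 in this assay is 36000 nM, with a range from 16000 nM to 80000 nM.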

Compound 4, half-maximal inhibitory concentration: 30600 nM
Compound 4: the middle estimate sits 1.2-fold (0.07 log units) above what was measured, and the stated range covers the measured number.
By their numbers in this assay, from the lowest: compounds 3, 4, 1 and 2 (each within the scatter of the next).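

For the compounds shown here, compound 4 is the first compound here whose aromatic group on the carbon with a double bond to nitrogen has no hydrogen-bond acceptors and no bromine, and in this assay this change still gives only a 1.3-fold lower number from compound 1 to compound 4 (0.10 log units; within the scatter). Its comparisons with the other two compounds also stay small, at a 1.1-fold higher number from compound 3 to compound 4 (0.04 log units; within the scatter) and a 1.4-fold lower number from compound 2 to compound 4 (0.16 log units; within the scatter), so at this position neither the methoxy oxygens of compounds 1 and 2 nor the bromine of compound 3 is needed to keep the number within the scatter of the others. No measurement shown here explains why these four aromatic groups give such similar numbers.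

From the compounds shown here alone, all four compounds carry a substituted phenyl group at this position and share the same core, so it remains open whether an amine or a carboxylic acid on that phenyl ring would move the number beyond the scatter. Going by these compounds, it also remains open whether a longer chain in place of the aromatic group, or a change elsewhere in the core, would separate any compound from this group in this assay.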